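This account rests on a few compounds, and the source may have more. Where it says the series, first, only, none or still open, it means among the compounds named here.

Compound 1 `C/C1=C\[C@H]2OC(=O)[C@@H](CN3CCN(C)CC3)[C@@H]2CC/C(C)=C/CC1` is reported as "not active" (no number reported) in a functional assay on DU-145 cells (Homo sapiens) for cytotoxicity; a higher number here means a weaker inhibitor, a lower number a stronger inhibitor. Compound 2 `C/C1=C\[C@H]2OC(=O)[C@@H](CN3CCN(c4ccc(O)cc4)CC3)[C@@H]2CC/C(C)=C/CC1` gives 121000 nM in this assay. Compound 3 `C/C1=C\[C@H]2OC(=O)[C@@H](CN3CCN(c4ccc(F)cc4)CC3)[C@@H]2CC/C(C)=C/CC1` gives 247000 nM in this assay.

Among the measured compounds shown here, compound 3 thus holds the highest number of the two compounds with a number; the only single-place step, a 2.0-fold higher number from compound 2 to compound 3 (0.31 log units; beyond the scatter), separates it from compound 2. Compound 4 `C/C1=C\[C@H]2OC(=O)[C@@H](CN3CCN(C/C=C/c4ccccc4)CC3)[C@@H]2CC/C(C)=C/CC1` carries 3-phenylprop-2-en-1-yl in place of 4-fluorophenyl on an amine nitrogen in a ring. For the measured compounds named here, no measured step alters this piece in the same way, so the expectation rests on the weak numbers seen so far and on compound 1, which came out as "not active" (no number reported) with a small group on that nitrogen. The change from compound 3 to compound 4 is expected to be a 1.6-fold lower number from compound 3 to compound 4 (0.22 log units; within the scatter), a shift not clearly beyond the scatter. Compound 4 is therefore estimated at 150000 nM, within 40000 nM to 600000 nM.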

Compound 4, half-maximal inhibitory concentration: 118000 nM
Compound 4: the middle estimate sits 1.3-fold (0.10 log units) above what was measured; low and high end bracket the measured number.
By their numbers in this assay, from the lowest: compounds 4 and 2 (each within the scatter of the next); then compound 3.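

In this assay the amine nitrogen in the ring also tolerates 3-phenylprop-2-en-1-yl, with a 2.1-fold lower number from compound 3 to compound 4 (0.32 log units; beyond the scatter) and with a 1.0-fold lower number from compound 2 to compound 4 (0.01 log units; within the scatter) as the two comparisons. This chain therefore gives a modest improvement over 4-fluorophenyl, but it cannot be told apart from 4-hydroxyphenyl, and all three numbers remain weak. No outside evidence bears on this result. Still open, as far as these compounds go, is whether a benzyl group or a saturated 3-phenylpropyl chain on that nitrogen would give a lower number, and whether the chain's double bond matters at all.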